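The compounds below may be only part of what the source reports. "The series", "measured", "known", "first", "only" and "open" are said of these compounds alone.

Compound 1 `COc1ccc(C(=O)/C=C/c2ccc(N(C)C)cc2)c2c1C=CC(C)(C)O2`, compound 2 `COc1ccc(C(=O)/C=C/c2ccc(OC)c(OC)c2OC)c2c1C=CC(C)(C)O2` and compound 3 `COc1ccc(C(=O)/C=C/c2ccco2)c2c1C=CC(C)(C)O2` were tested in a functional assay on HT-29 cells (Homo sapiens) for antiproliferative activity, read by MTT assay, with a stated time of 24 h; on this read-out lower numbers stand for stronger inhibition and higher numbers for weaker inhibition. Compound 1 gives 1870 nM. Compound 2 gives only a limit of the assay, > 10000 nM. Compound 3 likewise gives only a limit, > 10000 nM. Compound 3 therefore sits at the limit of > 10000 nM in this assay, at which 2 of the 3 values shown sit, so its true number is not known.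

The step to compound 4 `COc1ccc(C(=O)/C=C/c2cccc(O)c2)c2c1C=CC(C)(C)O2` is 3-hydroxyphenyl in place of furan-2-yl on a double-bonded chain carbon bound to a double-bonded chain carbon. Going by the values given here, one measured step concerns the same place: an at least 5.3-fold higher number from compound 1 to compound 3 (0.72 log units; beyond the scatter), where a different aryl group in place of furan-2-yl gave a real number. Because compound 1 reaches 1870 nM, a lower number is expected for compound 4, though 3-hydroxyphenyl was not itself measured. Compound 4 is expected near 6000 nM, between 1500 nM and 20000 nM, an estimated step of an at least 1.6-fold lower number from compound 3 to compound 4 (0.22 log units; that floor lies within the scatter).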

Compound 4, half-maximal inhibitory concentration: > 10000 nM
Compound 4: a limit, no number; the forecaster's own chance of this, stated with the estimate: 40%; middle value at least 1.6-fold (0.22 log units) away from the limit.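

With 3-hydroxyphenyl at this place, this assay gives an at least 5.3-fold higher number from compound 1 to compound 4 (0.72 log units; beyond the scatter), so a phenyl ring carrying a hydrogen-bond donor does not match 4-(dimethylamino)phenyl. The step between compound 3 and compound 4 cannot be read, as both values are limits. Compound 1 is now the only compound with a real number, while the other three share a limit: the limit of > 10000 nM in this assay, at which 3 of the 4 values shown sit.

From the compounds shown here alone, how far compound 2, compound 3 and compound 4 lie past that limit stays open. So does whether a simple amine, as in 4-aminophenyl, or a larger one, as in 4-(diethylamino)phenyl, would give a real number.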